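The source may hold more compounds than are shown below. What is called first, only, known or untested is meant among the compounds shown, and "the series" means these compounds.

Working notes on the amide series. All three measured compounds share one core and differ only in the aryl group on the carbonyl carbon. Compound 3 `CCN1CCN(c2cc(C)c3cc(NC(=O)c4ccc(F)cc4)ccc3n2)CC1` gives 4030 nM in a functional assay on MCF7 cells (Homo sapiens) for antiproliferative activity, read by MTT assay, with a stated time of 72 h (a higher number here means a weaker inhibitor, a lower number a stronger inhibitor), the lowest of the three numbers. Compound 2 `CCN1CCN(c2cc(C)c3cc(NC(=O)c4ccc(OC)cc4)ccc3n2)CC1` gives 7690 nM in this assay; compound 1 `CCc1ccccc1C(=O)Nc1ccc2nc(N3CCN(CC)CC3)cc(C)c2c1` gives 15800 nM in this assay. The step of a 3.9-fold lower number from compound 1 to compound 3 (0.59 log units; beyond the scatter) is beyond the scatter, as is a 2.1-fold lower number from compound 1 to compound 2 (0.31 log units; beyond the scatter); the step of a 1.9-fold lower number from compound 2 to compound 3 (0.28 log units; within the scatter) is within it, so compound 2 and compound 3 cannot be ordered.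

Compound 4 `CCN1CCN(c2cc(C)c3cc(NC(=O)c4ccccc4Cl)ccc3n2)CC1` is unmeasured in this assay. It differs from compound 3 in one place: 2-chlorophenyl in place of 4-fluorophenyl on a carbonyl carbon. The measured step that bears on it is a 3.9-fold lower number from compound 1 to compound 3 (0.59 log units; beyond the scatter), where 2-ethylphenyl was replaced by 4-fluorophenyl and the number fell; the step to compound 4 runs partly back toward a 2-substituted aryl, here 2-chlorophenyl. Among the compounds with values here, no measured pair contrasts chloro with fluoro on the aryl ring. Compound 4 is therefore expected to give a higher number than compound 3, with a step of a 2.2-fold higher number from compound 3 to compound 4 (0.35 log units; beyond the scatter) of modest size, though a change within the scatter cannot be ruled out. Compound 4 is estimated at 9000 nM, with a range of 3500 nM to 25000 nM.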

Compound 4, half-maximal inhibitory concentration: > 50000 nM
Compound 4: a limit, no number (the forecaster's own chance of this, stated with the estimate: 5%); middle value at least 5.5-fold (0.74 log units) away from the limit.
By their numbers in this assay, from the lowest: compounds 3 and 2 (each within the scatter of the next); then compound 1. At a limit, above all of these: compound 4.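

In this assay, compound 4 reads as a limit of the assay and not as a number: the limit of > 50000 nM in this assay, at which 1 of the 4 values shown sits. At this position, on a carbonyl carbon whose other neighbour is the amide-type nitrogen, the aryl group can therefore shift the read-out much further than compounds 1 to 3 showed: replacing 4-fluorophenyl with 2-chlorophenyl gives an at least 12-fold higher number from compound 3 to compound 4 (1.09 log units; beyond the scatter), and replacing 4-methoxyphenyl with 2-chlorophenyl gives an at least 6.5-fold higher number from compound 2 to compound 4 (0.81 log units; beyond the scatter). The two 2-substituted aryl groups are also not interchangeable, since chloro in place of ethyl on an aromatic carbon gives an at least 3.1-fold higher number from compound 1 to compound 4 (0.50 log units; beyond the scatter), so compound 1 stays within the measurable range while compound 4 does not.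

Each of these steps has only a lower bound, so their true sizes stay open, and the compounds shown do not separate the effect of the chloro group from that of its place on the ring. Also open, going by these compounds, is how an amine, a carboxylic acid or a longer chain on this aryl group would read, as the series here holds only ethyl, methoxy, fluoro and chloro.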